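Methoxy variant of compound 1 in the growth assay

This account rests on a few compounds, and the source may have more. Where it says the series, first, only, none or still open, it means among the compounds named here.

Measured so far:
compound 1 `Cc1nc(SCC(=O)Nc2nc(-c3ccc(Cl)cc3)cs2)n(Nc2ccccc2)c1C`: 7180 nM
compound 2 `Cc1ccc(Nn2c(SCC(=O)Nc3nc(-c4ccccc4)cs3)nc(C)c2C)cc1`: 22200 nM

In a functional assay on NCI/ADR-RES cells (Homo sapiens) for antiproliferative activity, read by sulforhodamine B assay, with a stated time of 48 h (a higher number here means a weaker inhibitor of growth, a lower number a stronger inhibitor of growth), compound 1 gives 7180 nM, the lowest of the two numbers. Compound 2 gives 22200 nM, a higher number beyond the scatter. Compounds 1 and 2 differ in more than one place, so no single step can be read from that pair. Compound 3 `COc1ccc(Nn2c(SCC(=O)Nc3nc(-c4ccc(Cl)cc4)cs3)nc(C)c2C)cc1` is not yet measured; it carries the change (methoxy in place of hydrogen on an aromatic carbon), methoxy in place of hydrogen on an aromatic carbon, para to a large group. For the measured compounds named here, no measured pair shows this change alone. A step of a 1.4-fold higher number from compound 1 to compound 3 (0.14 log units; within the scatter) toward a somewhat higher number is expected, at the edge of the scatter. Compound 3 is expected to give 10000 nM, between 3500 nM and 30000 nM.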

Compound 3, concentration for total growth inhibition: > 100000 nM
Compound 3 ended at the assay's limit (the forecaster's own chance of this, stated with the estimate: 10%); middle value at least 10-fold (1.00 log units) from the limit.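

In this assay, for the compounds shown here, methoxy in place of hydrogen on an aromatic carbon, para to a large group, gives an at least 13-fold higher number from compound 1 to compound 3 (1.14 log units; beyond the scatter), the first single-place step. This position on the anilino ring is therefore not indifferent to substitution: one methoxy takes compound 3 out of the measurable range. On these data alone, the value of compound 3, > 100000 nM, is a limit and not a number, so the full size of the step stays unknown.

As far as these compounds go, whether fluorine or an amine at this place would behave like methoxy remains open. So does whether the same step holds without the chlorine of compound 1.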